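A few compounds are considered here, and "the series" means these few. Any claim that something is new, unique, unknown or untested is made for them only; others in the source may bear on it.

In a functional assay for inhibition, with Rattus norvegicus as the target (on this read-out lower numbers stand for stronger inhibition and higher numbers for weaker inhibition), compound 1 (`CC(C)/N=c1\c(O)c(O)\c1=N/c1ccc(C#N)cc1`) gives 13700 nM as a measured number. Compound 2 (`CCCCCCC/N=c1\c(O)c(O)\c1=N/c1ccc(C#N)cc1`) shows only a limit, > 30000 nM, and no exact number. Compound 3 (`C[C@H](/N=c1\c(O)c(O)\c1=N/c1ccc(C#N)cc1)C1CCCCC1`) has 1-cyclohexylethyl in place of heptyl on a double-bonded nitrogen and has not yet been measured. Among the measured compounds shown here, the one measured step, an at least 2.1-fold higher number from compound 1 to compound 2 (0.34 log units; beyond the scatter), came with the arrival of heptyl, so removing heptyl is expected to lower the number in this assay, though this single step is thin support. The estimated change is an at least 3.3-fold lower number from compound 2 to compound 3 (0.52 log units; beyond the scatter), a modest drop. For compound 3 the expected value is 9000 nM, with an estimated range from 2000 nM to 28000 nM at this stage.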

Compound 3, half-maximal inhibitory concentration: > 30000 nM
Compound 3 ended at the assay's limit (the forecaster's own chance of this, stated with the estimate: 15%); middle value at least 3.3-fold (0.52 log units) from the limit.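

In this assay compound 3 gives > 30000 nM, which is a limit of the assay and not a number. With 1-cyclohexylethyl in place of isopropyl on the double-bonded nitrogen, the result is an at least 2.1-fold higher number from compound 1 to compound 3 (0.34 log units; beyond the scatter), so this ring-bearing group moves the number the same way as the open chain heptyl. The step between compound 2 and compound 3 cannot be read, since both stop at the limit: the limit of > 30000 nM in this assay, at which 2 of the 3 values shown sit.

Going by these compounds, the true values of compound 2 and compound 3 remain open. Also open, on these data alone, is whether methyl, cyclopropyl or a chain ending in an amine at this position would give a lower number than isopropyl.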